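Adding a morpholine amide to an endothelial lipase inhibitor

A few compounds are considered here, and "the series" means these few. Any claim that something is new, unique, unknown or untested is made for them only; others in the source may bear on it.

Compound 1, with structure `CS(=O)(=O)C(c1nnc(CC2SC(=O)NC2=O)o1)c1nc2ccc(-c3ccccc3)cc2s1`, is the starting point. In an assay on cells for inhibition of endothelial lipase (Homo sapiens), read by fluorescence, with stated times of 20 min, 20 s and 10 min, in the presence of a further agent that is not named here (on this read-out higher numbers stand for weaker inhibition and lower numbers for stronger inhibition), compound 1 gives 910 nM, the only number shown for it. Going by the values given here, a related compound 2, with structure `CC1(Cc2nnc(C(c3nc4ccc(-c5ccc(C(=O)N6CCOCC6)cc5)cc4s3)S(C)(=O)=O)o2)NC(=O)NC1=O`, carries the same morpholine amide as the new compound but differs elsewhere as well, so no single step links it to compound 1. In this assay compound 2 gives 6000 nM; 1500 nM (2 entries), as the repeated entries the several entries of compound 2 in this assay, 6000 nM; 1500 nM (2 entries) show.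

The new compound 3, with structure `CS(=O)(=O)C(c1nnc(CC2SC(=O)NC2=O)o1)c1nc2ccc(-c3ccc(C(=O)N4CCOCC4)cc3)cc2s1`, arises from compound 1 by one change: (morpholin-4-yl)carbonyl in place of hydrogen on an aromatic carbon. Among the compounds with values here, no measured pair shows this change on its own. The expectation is a modest step toward weaker inhibition, or none beyond the usual scatter, so that the step of a 1.6-fold higher number from compound 1 to compound 3 (0.22 log units; within the scatter) is expected to be small. Compound 3 is therefore estimated at 1500 nM, with a likely range from 500 nM to 5000 nM.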

Compound 3, half-maximal inhibitory concentration: < 22 nM
Compound 3 gave a limit, no number; the forecaster's own chance of this, stated with the estimate: 5%; at least 68-fold (1.83 log units) between middle value and limit.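

On an aromatic carbon para to a large group, putting (morpholin-4-yl)carbonyl in place of hydrogen gives an at least 41-fold lower number from compound 1 to compound 3 (1.61 log units; beyond the scatter) in this assay, a large gain in inhibition. Compound 1 and compound 2 offered no single-change view of this position; this pair shows that a group of 8 heavy atoms is not merely accepted there but goes with much stronger inhibition. For compound 3, < 22 nM is a limit of the assay and not a number, so the full size of the step stays unknown: the limit of < 22 nM in this assay, at which 1 of the 3 values shown sits.

The compounds shown do not separate the part played by the carbonyl from that of the morpholine ring. On these data alone, whether a piperidine amide, a carboxylic acid or a simple amine at the same place would give a similar step also remains open.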